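A Chloro Added to the Aryl Piperazine of Compound 2

The source may report more compounds than this note shows. Statements on the series, on what has been measured and on what is new or still open speak of the compounds shown alone.

Compound 2 `CC(C)(C)c1ccc(-c2nn(CCCN3CCN(c4ccccc4)CC3)c(=S)[nH]2)cc1` was tested in a functional assay on THP-1 cells (Homo sapiens) for cytotoxicity, read by MTT assay, with a stated time of 24 h (on this read-out lower numbers stand for stronger inhibition and higher numbers for weaker inhibition), where compound 2 gives 147000 nM. Among the two measured compounds this is the only numerical value shown. Compound 1 `Cc1ccc(-c2nnc(SCCCN3CCN(c4cccc(Cl)c4)CC3)[nH]2)cc1` reaches only a limit of the assay, > 300000 nM. One of the two values thus sits at the limit of > 300000 nM in this assay, at which 1 of the 2 values shown sits. Compound 3 `CC(C)(C)c1ccc(-c2nn(CCCN3CCN(c4cccc(Cl)c4)CC3)c(=S)[nH]2)cc1` has not yet been measured. It differs from compound 2 by chloro in place of hydrogen on an aromatic carbon. Within the data shown here, no step between two measured compounds is available to gauge the effect of such a change, so nothing measured points in either direction. The step from compound 2 to compound 3 is expected to be a 1.0-fold higher number from compound 2 to compound 3 (0.01 log units; within the scatter), which is no change beyond the scatter. Compound 3 is therefore estimated at 150000 nM in this assay, with a range from 60000 nM to 400000 nM.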

Compound 3, half-maximal inhibitory concentration: > 300000 nM
Compound 3: a limit, no number; the forecaster's own chance of this, stated with the estimate: 35%; middle value at least 2.0-fold (0.30 log units) from the limit.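

In this assay, among these compounds, chloro in place of hydrogen on an aromatic carbon, the change from phenyl to 3-chlorophenyl, gives the first reading at this position: an at least 2.0-fold higher number from compound 2 to compound 3 (0.30 log units; that floor lies within the scatter). Among the compounds shown here, the result shows only that the chloro compound gives no number in this read-out, so the step has a floor but no measured size, and that floor does not set it apart from no change. The reading is open on one side, and a second compound now rests on the assay's limit: the limit of > 300000 nM in this assay, at which 2 of the 3 values shown sit.

On these data alone, whether a fluoro group, a methoxy group or an amine on the same aromatic carbon would give a lower number than chloro stays open. So does whether a longer chain in the linker would alter the value of compound 2.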